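The compounds below may be only part of what the source reports. "The series", "measured", "known", "first", "only" and "open" are said of these compounds alone.

Compound 1, `O=C(O)/C=C/c1cn(-c2ccc(O)cc2)nc1-c1cccc(O)c1`: in a functional assay (Mus musculus) for inhibition, with a stated time of 5 days (a lower number here means a stronger inhibitor, a higher number a weaker inhibitor), compound 1 gives > 100000 nM, a limit of the assay.
Compound 2, `CCOC(=O)/C=C/c1cn(-c2ccc(O)cc2)nc1-c1cccc(O)c1`: in this assay compound 2 gives 14000 nM.
Compound 3, `O=C(O)/C=C/c1cn(-c2ccc(O)cc2)nc1-c1cc(O)ccc1O`: in this assay compound 3 gives > 100000 nM, again a limit of the assay.

Among the measured compounds shown here, compound 2 thus holds the only number in this set; the other two values sit at the limit of > 100000 nM in this assay, at which 2 of the 3 values shown sit. The step of an at least 7.1-fold lower number from compound 1 to compound 2 (0.85 log units; beyond the scatter) is beyond the scatter. The step that the two limits leave unreadable from compound 1 to compound 3 has limits at both ends and cannot be read.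

Compound 4, `CCOC(=O)/C=C/c1cn(-c2ccc(O)cc2)nc1-c1ccc(O)c(O)c1`, differs from compound 2 by hydroxy in place of hydrogen on an aromatic carbon. For the measured compounds named here, the one measured step with the same change, from compound 1 to compound 3, gives no readable size, and no measured step shows this change on a compound with a number. No direction beyond the scatter is expected, with wide uncertainty. Compound 4 is estimated at 20000 nM, between 5000 nM and 100000 nM. The expected step is a 1.4-fold higher number from compound 2 to compound 4 (0.15 log units; within the scatter).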

Compound 4, half-maximal inhibitory concentration: 6200 nM
Compound 4: the middle estimate sits 3.2-fold (0.51 log units) above what was measured, within the range that was stated.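

On the ester, hydroxy in place of hydrogen, ortho to a hydroxy group and para to a large group, gives a 2.3-fold lower number from compound 2 to compound 4 (0.35 log units; beyond the scatter) in this assay. Among the compounds shown here, this is the first readable size for this change, and it shows that the position takes a second hydroxy with a modest gain. The earlier step with this change cannot be read, with limits at both ends: the limit of > 100000 nM in this assay, at which 2 of the 4 values shown sit. From the compounds shown here alone, whether a methoxy group or an amine at this position would do the same stays open, as does the effect of this 3,4-dihydroxyphenyl pattern on the carboxylic acid.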